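A Second Ring Nitrogen on the Piperazine Arm

A few compounds are considered here, and "the series" means these few. Any claim that something is new, unique, unknown or untested is made for them only; others in the source may bear on it.

Two measured compounds share one core and differ only in the group that sits on an amine nitrogen in a ring. Compound 1 `Nc1ccccc1NC(=O)c1ccc(CSC(=S)N2CCN(C(c3ccccc3)c3ccccc3)CC2)cc1` carries a large group there; in a functional assay on HeLa cells (Homo sapiens) for antiproliferative activity, read by CCK-8 assay, with a stated time of 72 h, tested at 8 uM (a higher number here means a stronger effect of the compound at the concentration tested, a lower number a weaker effect), compound 1 gives 13.8%. Compound 2 `Nc1ccccc1NC(=O)c1ccc(CSC(=S)N2CCN(c3cccnc3)CC2)cc1` carries pyridin-3-yl at that place, and in this assay compound 2 gives 72.5%, the higher of the two numbers, with a gap to compound 1 that lies beyond the usual scatter.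

Compound 3 `Nc1ccccc1NC(=O)c1ccc(CSC(=S)N2CCN(c3ncccn3)CC2)cc1` keeps the core of compound 2 and alters one thing: pyrimidin-2-yl in place of pyridin-3-yl on an amine nitrogen in a ring. Both the leaving and the entering group are single six-membered aromatic rings, the entering one with two hetero atoms instead of one. Among the measured compounds shown here, no measured pair shows this exact exchange, so the size of the step is uncertain. Because compound 2 gives 72.5% with a six-membered aromatic ring in that place, the step of a number 10.5 percentage points lower from compound 2 to compound 3 (beyond the scatter) is expected to be small, perhaps a modest decrease, rather than a collapse. In this assay compound 3 is estimated at 62%, within a range from 35% to 85%.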

Compound 3, a percentage reported as inhibition, at one concentration (the size of the read-out at that concentration, not a potency): 73.9%
For compound 3 the middle estimate is 11.9 percentage points below the measured one; the range from low to high includes it.
By their numbers in this assay, from the lowest: compound 1; then compounds 2 and 3 (each within the scatter of the next).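

In this assay the exchange of pyridin-3-yl for pyrimidin-2-yl is a number 1.4 percentage points higher from compound 2 to compound 3 (within the scatter) and so leaves the two compounds indistinguishable in this read-out. The earlier pair showed that the group on this ring nitrogen can matter a great deal, whereas this step shows that a single six-membered aromatic ring with 2 hetero atoms and 2 hydrogen-bond acceptors serves here as well as one with 1 of each. No measurement at hand explains why these two rings give such similar readings.

Each reading is the size of the effect at one concentration rather than a potency, so compound 2 and compound 3 could still differ at other concentrations. Also open, on these data alone, is whether a plain phenyl ring, a five-membered thiazol-2-yl ring or a small methyl group on the same ring nitrogen would keep the reading of these two compounds, and how large a group can sit there before the reading falls toward that of compound 1.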